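A few compounds are considered here, and "the series" means these few. Any claim that something is new, unique, unknown or untested is made for them only; others in the source may bear on it.

Measured so far:
compound 1, `CC(C)c1cc(-c2ccc(Cl)cc2)[nH]c1-c1ccncc1` — 3030 nM
compound 2, `O=C(O)c1cc(-c2ccc(Cl)cc2)[nH]c1-c1ccncc1` — > 3000 nM

Compound 1 carries an isopropyl group and in an assay on CHO cells for binding affinity to Glucagon receptor (Homo sapiens), in the absence of a further agent (on this read-out lower numbers stand for stronger inhibition and higher numbers for weaker inhibition), compound 1 gives 3030 nM. Compound 2 carries a carboxy group in the same place, and in this assay compound 2 gives > 3000 nM, which is a limit of the assay rather than a number. Compound 2 therefore stands only at the limit of > 3000 nM in this assay, at which 1 of the 2 values shown sits, and the step that the limit leaves unreadable from compound 1 to compound 2 cannot be read. The next compound is compound 3, `Clc1ccc(-c2cc(C3CCCCC3)c(-c3ccncc3)[nH]2)cc1`, which differs from compound 2 by cyclohexyl in place of carboxy on an aromatic carbon. Going by the values given here, the single measured step from compound 1 to compound 2 is the only one that bears on this change, and its size is hidden by the limit, so it gives no direction. The cyclohexyl group of compound 3 resembles the isopropyl group of compound 1 more than it does the carboxy group of compound 2. Because compound 1 gives 3030 nM, compound 3 is estimated at 2500 nM, with a range from 700 nM to 9000 nM. The step this estimate implies from compound 2 to compound 3 is an at least 1.2-fold lower number from compound 2 to compound 3 (0.07 log units; that floor lies within the scatter), but it is expected only loosely, since it starts from a limit.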

Compound 3, half-maximal inhibitory concentration: 100 nM
Estimate against measurement, compound 3: 25-fold (1.40 log units) above, outside the stated range (below it).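

In this assay, the aromatic carbon next to the ring atom that bears a pyridin-4-yl group proves sensitive to the group it carries, which the earlier pair could not show: cyclohexyl in place of isopropyl gives a 30-fold lower number from compound 1 to compound 3 (1.48 log units; beyond the scatter). Cyclohexyl in place of carboxy gives an at least 30-fold lower number from compound 2 to compound 3 (1.47 log units; beyond the scatter), so a ring of six carbons at this position reads far lower than either of the two smaller groups. Compound 2 stands as a limit of the assay and not a number, so this second step is only a floor and the step between compound 1 and compound 2 remains unreadable: the limit of > 3000 nM in this assay, at which 1 of the 3 values shown sits.

With three groups shown at this carbon, it stays open whether the drop follows the ring itself or only the larger count of carbon atoms, a question that cyclopentyl, phenyl or an open chain such as n-hexyl would separate. Also open, as far as these compounds go, is how an amine or an amide would read at this carbon, and whether the gain from cyclohexyl holds when the 4-chlorophenyl or pyridin-4-yl group is replaced.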